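Adding a methoxy to compound 3

This account rests on a few compounds, and the source may have more. Where it says the series, first, only, none or still open, it means among the compounds named here.

Of the compounds shown here, three sharing one core have been measured so far. In a functional assay on HCT-116 cells (Homo sapiens) for cytotoxicity, read by MTT assay, with a stated time of 72 h (a lower number here means a stronger inhibitor, a higher number a weaker inhibitor), compound 1 `COc1cc(Nc2nc3ccccc3nc2S(=O)(=O)c2ccccc2)cc(OC)c1` gives 950 nM while compound 2 `Nc1ccc(Nc2nc3ccccc3nc2S(=O)(=O)c2ccccc2)cc1` gives 10800 nM and compound 3 `O=S(=O)(c1ccccc1)c1nc2ccccc2nc1Nc1ccc(F)cc1` gives 5190 nM (second highest of the three). Its two neighbours sit on either side of it (a 2.1-fold lower number from compound 2 to compound 3 (0.32 log units; beyond the scatter) and a 5.5-fold higher number from compound 1 to compound 3 (0.74 log units; beyond the scatter)).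

Compound 4 `COc1ccc(S(=O)(=O)c2nc3ccccc3nc2Nc2ccc(F)cc2)cc1` differs from compound 3 in one place: methoxy in place of hydrogen on an aromatic carbon, so that phenyl becomes 4-methoxyphenyl (methoxy in place of hydrogen on an aromatic carbon). The new group stands para to a large group.

All three measured steps, the largest being an 11-fold higher number from compound 1 to compound 2 (1.06 log units; beyond the scatter) (large), changed the group on a nitrogen. None of them tests the place that changes here, so they show only how far this assay can move among close relatives. Among the measured compounds shown here, compound 1 (at 950 nM) is the only measured compound carrying methoxy groups and has the lowest number, yet those groups sit elsewhere, which makes it a weak hint towards a lower number.

The expected result is therefore small, with no step beyond the scatter (a 1.3-fold lower number from compound 3 to compound 4 (0.11 log units; within the scatter)). Compound 4 is estimated at 4000 nM (expected range 1300 nM to 11000 nM).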

Compound 4, half-maximal inhibitory concentration: 2110 nM
Beside the measured number, compound 4's estimate is 1.9-fold (0.28 log units) above it; measured number inside the range.
By their numbers in this assay, from the lowest: compound 1; then compound 4; then compound 3; then compound 2.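

The phenyl that becomes 4-methoxyphenyl turns out to be a place where a single small addition counts in this assay: the step is a 2.5-fold lower number from compound 3 to compound 4 (0.39 log units; beyond the scatter). Among the compounds shown here, every earlier step changed the group on a nitrogen, so this is the first sign that the other side of the shared core also moves the number beyond the scatter. The step is modest, and smaller than the largest step seen on the nitrogen, an 11-fold higher number from compound 1 to compound 2 (1.06 log units; beyond the scatter), but it shows that methoxy, para to a large group, is accepted here and goes with a lower number, with no measurement shown to explain why.

With only hydrogen and methoxy compared at this place, one step cannot show whether a lower number follows from methoxy in particular or from almost any added group, and a chlorine atom, an amine, a carboxylic acid or a longer chain such as butoxy would each test that. On these data alone, it also stays open whether the same methoxy would lower the number by a similar step when the group on the nitrogen is the 3,5-dimethoxyphenyl of compound 1 rather than 4-fluorophenyl.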